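Ester reversal on the side chain of compound 3

The compounds below may be only part of what the source reports. "The series", "measured", "known", "first", "only" and "open" are said of these compounds alone.

Measured in a functional assay on B16 cells (Mus musculus) for cytotoxicity, read by MTT assay, with a stated time of 48 h; on this read-out lower numbers stand for stronger inhibition and higher numbers for weaker inhibition:
- compound 1 `C#CC(=O)Nc1ccc(C#C)cc1`: 6300 nM
- compound 2 `C#Cc1ccc(NC(=O)c2cn(Cc3ccccc3)nn2)cc1`: > 100000 nM (a limit)
- compound 3 `C#Cc1ccc(NC(=O)c2cn(CC(=O)OCC)nn2)cc1`: > 100000 nM (a limit)

Compound 1 is the only one of the three with a measured number. Compound 3 has no number, only the limit > 100000 nM. The same limit applies to compound 2, as the limit of > 100000 nM in this assay, at which 2 of the 3 values shown sit, records.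

Compound 4 `C#Cc1ccc(NC(=O)c2cn(CCOC(C)=O)nn2)cc1` has the same atoms as compound 3, joined differently: acetoxymethyl in place of ethoxycarbonyl on a saturated chain carbon bound to an aromatic nitrogen. The same difference, cut one bond further out, reads (ethoxycarbonyl)methyl to 2-acetoxyethyl.

Within the data shown here, one measured step bears on this change: a step that the two limits leave unreadable from compound 2 to compound 3. It offers no size to carry over, so no step beyond the scatter and no direction is expected in this assay. Compound 4 is expected to stay near compound 3, most likely reported as the same limit.

The step expected is a number no higher from compound 3 to compound 4 (the limit leaves the size open).

For compound 4 the estimated value is 100000 nM, with an expected range from 40000 nM to 250000 nM.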

Compound 4, half-maximal inhibitory concentration: 79000 nM
The estimate for compound 4 lay 1.3-fold (0.10 log units) above the measured number, within the range that was stated.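

Among the compounds carrying a chain on a saturated chain carbon bound to an aromatic nitrogen, compound 4 alone gives a number rather than a limit in this assay, at 79000 nM. The ester reversal reads as an at least 1.2-fold lower number from compound 3 to compound 4 (0.10 log units; that floor lies within the scatter), and the replacement of phenyl reads as an at least 1.2-fold lower number from compound 2 to compound 4 (0.10 log units; that floor lies within the scatter); both are floors, so neither establishes a change beyond the scatter. The step between compound 2 and compound 3 cannot be read, and one boundary constrains every comparison here: the limit of > 100000 nM in this assay, at which 2 of the 4 values shown sit.

From the compounds shown here alone, how far compound 4 truly lies from compound 3 remains open, as the value of compound 3 is only a limit. A carboxylic acid, an amine or a longer chain at this place could show whether this assay gives numbers well clear of that limit.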